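The source may report more compounds than this note shows. Statements on the series, on what has been measured and on what is new or still open speak of the compounds shown alone.

Measured in a functional assay on VCaP cells (Homo sapiens) for antiproliferative activity, read by CCK-8 assay, with a stated time of 6 days; a lower number here means a stronger inhibitor, a higher number a weaker inhibitor:
- Compound 1 `C[C@@H](Cn1ccc(-c2ccc(C#N)c(Cl)c2)n1)Nc1ccccc1`: > 30000 nM
- Compound 2 `C[C@@H](Cn1ccc(-c2ccc(C#N)c(Cl)c2)n1)Nc1ncnc2nc[nH]c12`: 640 nM

Compound 1 gives the reading > 30000 nM, which is a limit of the assay and not a number. Among the measured compounds shown here, compound 2, at 640 nM, therefore holds the only true number in this assay. For the measured compounds named here, the single measured step, an at least 46-fold lower number from compound 1 to compound 2 (1.67 log units; beyond the scatter), exchanges the group on the amine nitrogen.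

Compound 3 `C[C@H](Cn1ccc(-c2ccc(C#N)c(Cl)c2)n1)Nc1ncnc2nc[nH]c12` departs from compound 2 only in this way: the two compounds have the same atoms and bonds and differ only in configuration as drawn: 1 of 1 stereo elements differ; a stereocentre at a saturated chain carbon is drawn S in compound 2 and R in compound 3. The measured step leaves that stereocentre untouched, so it sets no size for the inversion. With compound 2 at 640 nM as the sole anchor, a moderate move to a higher number is expected, though a change within the scatter remains possible. The estimated step is a 2.3-fold higher number from compound 2 to compound 3 (0.37 log units; beyond the scatter). For compound 3 the expected value is 1500 nM, with an estimated range of 350 nM to 8000 nM.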

Compound 3, half-maximal inhibitory concentration: 2000 nM
Estimate against measurement, compound 3: 1.3-fold (0.12 log units) below; measured number inside the range.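

In this assay, inverting the stereocentre at the saturated chain carbon gives a 3.1-fold higher number from compound 2 to compound 3 (0.49 log units; beyond the scatter), so the configuration at this position changes the reading by itself. The earlier step exchanged the group on the amine nitrogen, whereas here every atom and bond stays in place, and the shift can be traced to the inversion alone: the fact that compounds 2 and 3 differ only in the configuration as drawn. The S form as drawn in compound 2 has the lower number, yet compound 3 with the R form still gives a true number and not a limit, so the inversion weakens the reading without removing it.

From the compounds shown here alone, it remains open whether the same order of the two forms holds with other groups on the amine nitrogen. Going by these compounds, it is also open how an ethyl group in place of the methyl group on that chain carbon, or a chain without the methyl group and so without a stereocentre, would read.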